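The source may report more compounds than this note shows. Statements on the series, on what has been measured and on what is new or still open speak of the compounds shown alone.

Measured compounds:
compound 1, `CCCOCNc1n[n+]([O-])c2cc(OC)ccc2[n+]1[O-]` — in a functional assay on PC-3 cells (Homo sapiens) for cytotoxicity, read by MTT assay, with a stated time of 72 h (on this read-out lower numbers stand for stronger inhibition and higher numbers for weaker inhibition), compound 1 gives 6570 nM
compound 2, `COCNc1n[n+]([O-])c2ccccc2[n+]1[O-]` — compound 2 gives 7510 nM
compound 3, `COc1ccc2c(c1)[n+]([O-])nc(NCOC(C)c1ccccc1)[n+]2[O-]` — compound 3 gives 4140 nM

All three share the same core and differ only in the group carried on the oxygen of the side chain. Compound 2 stands at the top of the three numbers, yet the gaps to compound 1 and to compound 3 are both within the usual scatter, so the three are best read as one cluster with no settled order.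

Compound 4, `CCOCNc1n[n+]([O-])c2ccccc2[n+]1[O-]`, is compound 2 with one change: methyl in place of hydrogen on a saturated chain carbon bound to an oxygen on a saturated carbon. Among the measured pairs, only the step of a 1.6-fold lower number from compound 1 to compound 3 (0.20 log units; within the scatter) touches the same part of the molecule, swapping one alkyl group on the oxygen for another, and it stayed within the scatter. Compound 4 makes a smaller change of the same kind, so in this assay no shift beyond the scatter is expected; the step of a 1.1-fold lower number from compound 2 to compound 4 (0.04 log units; within the scatter) is the estimated outcome. Compound 4 is therefore expected to give about 6800 nM, with a range from 3200 nM to 14000 nM.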

Compound 4, half-maximal inhibitory concentration: 15900 nM
Compound 4: middle estimate off by 2.3-fold (0.37 log units), on the low side; measured number outside the range, above it.
By their numbers in this assay, from the lowest: compounds 3, 1 and 2 (each within the scatter of the next); then compound 4.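

In this assay, going from methoxymethyl to ethoxymethyl gives a 2.1-fold higher number from compound 2 to compound 4 (0.33 log units; beyond the scatter), so adding one methyl at this place is enough to move the number beyond the scatter, towards weaker inhibition. Within the data shown here, until now, the only step that changed the group on this oxygen was a 1.6-fold lower number from compound 1 to compound 3 (0.20 log units; within the scatter), on the core of compound 1, which stayed within the scatter even though the swap was larger; the new step shows that, at least on the core of compound 2, the group on this oxygen can matter, and that a larger change there does not reliably mean a larger shift in the number. Nothing available here explains why this small change counts.

Going by these compounds, it remains open whether the same methyl step would shift the number on the core of compound 1, where a methoxy group is also present. On these data alone, it is also open how the number would respond if a longer chain such as butyl, or an amine at the end of the chain, were carried on this oxygen, since one step beyond the scatter does not establish a trend.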